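Swapping a Furan for a Butyl Chain

The source may report more compounds than this note shows. Statements on the series, on what has been measured and on what is new or still open speak of the compounds shown alone.

Compound 1 `C=C1CC[C@@H]2[C@](C)(COC(=O)/C=C/c3cccc(OC)c3)[C@H](O)CC[C@@]2(C)[C@@H]1/C=C/C1=CCOC1=O`: > 1970000 nM
Compound 2 `C=C1CC[C@@H]2[C@](C)(CO)[C@H](OC(=O)c3ccco3)CC[C@@]2(C)[C@@H]1C/C=C1\C=COC1=O`: 42000 nM

Both compounds were tested for harm to liver-derived cells in an ADME assay on HepG2 2.2.15 cells (Homo sapiens) for cytotoxicity, read by MTT assay; a lower number here means that less compound is tolerated, a higher number that more compound is tolerated. Compound 1 gives > 1970000 nM, which is a limit of the assay and not a number. Going by the values given here, that leaves compound 2, at 42000 nM, with the only true number available, so it is the sole firm anchor for what comes next.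

Compound 3 `C=C1CC[C@@H]2[C@](C)(CO)[C@H](OC(=O)CCCC)CC[C@@]2(C)[C@@H]1C/C=C1\C=COC1=O` keeps the rest of compound 2 and changes one group, with butyl in place of furan-2-yl on a carbonyl carbon. Among the compounds with values here, no pair of measured compounds isolates a swap like this one, so the expectation rests on little. A small step in this assay seems most likely, leaning towards more compound being tolerated and not far beyond the usual scatter of repeat measurements. The expected change is a 1.4-fold higher number from compound 2 to compound 3 (0.15 log units; within the scatter). For compound 3 the estimated value is 60000 nM, with an expected range from 20000 nM to 250000 nM.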

Compound 3, half-maximal cytotoxic concentration: 126000 nM
Estimate against measurement, compound 3: 2.1-fold (0.32 log units) below; low and high end bracket the measured number.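

Going by these compounds alone, this is the first step that can be read as a single change: on a carbonyl carbon whose other neighbour is the oxygen of the ester, butyl in place of furan-2-yl gives a 3.0-fold higher number from compound 2 to compound 3 (0.48 log units; beyond the scatter). So in this assay this position is not silent, since replacing a five-membered aromatic ring with an open chain of carbon atoms moves the number by more than repeat measurements would blur. Compound 1 adds no second number for judging this swap, as it differs from compound 2 in more than one place and its value is a limit of the assay, not a number: the limit of > 1970000 nM in this assay, at which 1 of the 3 values shown sits.

Going by these compounds, one swap removes the ring and its oxygen together, so it remains open which of the two losses goes with the higher number. A thiophene or phenyl ring in the same place would test the ring without that oxygen, while a hexyl chain would show whether the number keeps rising as the chain grows longer or whether butyl is simply one point with no trend behind it.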